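A few compounds are considered here, and "the series" means these few. Any claim that something is new, unique, unknown or untested is made for them only; others in the source may bear on it.

Compound 1 `Cc1ccc(S(=O)(=O)/N=C(/CCNC2=CC(=O)c3ccccc3C2=O)Nc2ccc(Cl)cc2)cc1`: in a functional assay on MCF7 cells (Homo sapiens) for cytotoxicity, read by MTT assay, with a stated time of 48 h (on this read-out lower numbers stand for stronger inhibition and higher numbers for weaker inhibition), compound 1 gives 7080 nM.
Compound 2 `Cc1ccc(S(=O)(=O)/N=C(/CCNC2=CC(=O)c3ccccc3C2=O)Nc2cccc(C)c2)cc1`: compound 2 gives 8120 nM.
Compound 3 `Cc1ccc(S(=O)(=O)/N=C(/CCNC2=CC(=O)c3ccccc3C2=O)Nc2cccc(C(F)(F)F)c2)cc1`: compound 3 gives 89100 nM.

All three share one core and differ only in the aromatic group on the amine nitrogen. Compound 1 and compound 2 cannot be told apart, since the step of a 1.1-fold higher number from compound 1 to compound 2 (0.06 log units; within the scatter) lies within the scatter. Compound 3 stands clearly apart from both, as the steps of a 13-fold higher number from compound 1 to compound 3 (1.10 log units; beyond the scatter) and an 11-fold higher number from compound 2 to compound 3 (1.04 log units; beyond the scatter) show; here a trifluoromethyl instead of a methyl made a large difference.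

Compound 4 `COc1ccc(N/C(CCNC2=CC(=O)c3ccccc3C2=O)=N\S(=O)(=O)c2ccc(C)cc2)c(OC)c1` carries a new group at that same place: 2,4-dimethoxyphenyl in place of 4-chlorophenyl on an amine nitrogen. For the measured compounds named here, no measured step involves a methoxy group, so nothing speaks directly to this change. What the data do show is that one small substituent left the number unchanged while another raised it a lot, so the outcome of a new substituent here is hard to call. A moderate rise beyond the scatter is expected, with wide uncertainty: compound 4 is estimated to sit at 12000 nM, between 3500 nM and 45000 nM, corresponding to an expected step of a 1.7-fold higher number from compound 1 to compound 4 (0.23 log units; within the scatter).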

Compound 4, half-maximal inhibitory concentration: 30200 nM
Estimate against measurement, compound 4: 2.5-fold (0.40 log units) below; the measured number falls inside the stated range.
By their numbers in this assay, from the lowest: compounds 1 and 2 (each within the scatter of the next); then compound 4; then compound 3.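

In this assay, the aromatic group on the amine nitrogen now gives a third level of response: the steps of a 4.3-fold higher number from compound 1 to compound 4 (0.63 log units; beyond the scatter) and a 3.7-fold higher number from compound 2 to compound 4 (0.57 log units; beyond the scatter) lie beyond the scatter, yet the step of a 3.0-fold lower number from compound 3 to compound 4 (0.47 log units; beyond the scatter) shows that 2,4-dimethoxyphenyl does not reach the high number of compound 3. This position therefore does not simply split into groups that leave the number unchanged and groups that raise it greatly, since 2,4-dimethoxyphenyl, with 2 hydrogen-bond acceptors where 4-chlorophenyl has 0, lands in the middle of the set. No available evidence bears on why these groups fall in this order.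

Because compound 4 carries two methoxy groups on its ring, these compounds cannot show how much of the step comes from either one, and a phenyl ring with a single methoxy or with no substituent at all would help separate those contributions. On these data alone, whether a group of a different kind on the ring, such as an amine or a carboxylic acid, would lower the number below that of compound 1 also remains open.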